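The source may report more compounds than this note shows. Statements on the series, on what has been measured and on what is new or still open speak of the compounds shown alone.

Compound 1 `COc1cccc(CNCCCNc2ccnc3cc(Cc4cc(C)cc(C)c4)ccc23)c1O` in a physicochemical assay for acid dissociation, gives 9.47. Compound 2 `COc1ccc(F)cc1CNCCCNc1ccnc2cc(Cc3cc(C)cc(C)c3)ccc12` gives 9.47 in this assay. The one measured step, no change at the digits printed from compound 1 to compound 2 (within the scatter), sets 5-fluoro-2-methoxyphenyl in place of 2-hydroxy-3-methoxyphenyl on a saturated chain carbon bound to an amine nitrogen, so on the numbers shown compound 1 stands level with compound 2 at the digits printed, within the scatter.

Compound 3 `COc1cccc(CNCCCNc2ccnc3cc(-c4ccc(C(F)(F)F)cc4)ccc23)c1O` has not yet been run in this assay. It differs from compound 1 by 4-(trifluoromethyl)phenyl in place of 3,5-dimethylbenzyl on an aromatic carbon on an aromatic carbon of the shared core, part of a fused or bridged system of two rings. Going by the values given here, the only measured step that bears on it is the flat one from compound 1 to compound 2, and that step altered the group on the saturated chain carbon bound to the amine nitrogen, not a group on the core; no step at the core has been measured. Among the compounds with values here, with that one flat step as the sole guide, the expected step for compound 3 is a number 0.07 log units lower from compound 1 to compound 3 (within the scatter), none beyond the scatter in this assay. The estimate for compound 3 is 9.4, with a range from 9 to 9.8.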

Compound 3, acid dissociation constant: 9.47
Estimate against measurement, compound 3: 0.07 log units below; measured number inside the range.
By their numbers in this assay, from the lowest: compounds 1, 2 and 3 (each within the scatter of the next).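

In this assay, the only step at the core among the compounds shown reads no change at the digits printed from compound 1 to compound 3 (within the scatter); 3,5-dimethylbenzyl leaves and 4-(trifluoromethyl)phenyl enters. The aromatic carbon concerned, meta to a fused ring and para to a fused ring, therefore carries a group of 10 heavy atoms, 7 carbon and 3 fluorine, in place of one of 9 heavy atoms, all carbon, with no shift beyond the scatter, so the read-out is now flat for one change at the core as well as for the change on the saturated chain carbon, no change at the digits printed from compound 1 to compound 2 (within the scatter). No measurement at hand gives a reason why either step is flat.

As far as these compounds go, both groups at this position hold one six-membered aromatic ring of carbon only and have 0 hydrogen-bond donors and 0 hydrogen-bond acceptors, so what an amine or a carboxylic acid on the same aromatic carbon would give in this assay remains open. Also open, from the compounds shown here alone, is whether the step at the core stays flat when 5-fluoro-2-methoxyphenyl stands in place of 2-hydroxy-3-methoxyphenyl on the saturated chain carbon.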